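This account rests on a few compounds, and the source may have more. Where it says the series, first, only, none or still open, it means among the compounds named here.

Within the data shown here, compound 1 `N[C@H](CN(C(=O)[C@@H]1C[C@H]1c1ccccc1)c1ccc(-c2ccccc2)cc1)C1CCCCC1` stands lowest of the two numbers so far in a functional assay for agonist activity at G protein-coupled receptor 88 (Homo sapiens), read by HTRF and cAMP accumulation; a higher number here means that more compound is needed for the effect, a lower number that less compound is needed: compound 1 gives 0.66 nM. The other measured compound is compound 2 `CC(C)(N)CN(C(=O)[C@@H]1C[C@H]1c1ccccc1)c1ccc(-c2ccccc2)cc1`, and in this assay compound 2 gives 1.4 nM. Among the measured compounds shown here, the single measured step, a 2.1-fold higher number from compound 1 to compound 2 (0.33 log units; beyond the scatter), shows that removing the six-membered ring from the chain carbon bound to the amide-type nitrogen costs a little potency.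

Compound 3 `CC(C)CCNCCN(C(=O)[C@@H]1C[C@H]1c1ccccc1)c1ccc(-c2ccccc2)cc1` has not yet been measured. It differs from compound 1 in one place: (isopentylamino)methyl in place of amino(cyclohexyl)methyl on a saturated chain carbon bound to an amide-type nitrogen. The step from compound 1 to compound 2 is the only one that bears on this change, and it was modest; the change to compound 3 also drops the ring, so a loss at least as large is expected, with an estimated step of a 3.0-fold higher number from compound 1 to compound 3 (0.48 log units; beyond the scatter). Compound 3 is therefore expected to give about 2 nM in this assay, estimated within 0.6 nM to 8 nM.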

Compound 3, half-maximal effective concentration: 5.1 nM
Beside the measured number, compound 3's estimate is 2.6-fold (0.41 log units) below it; the range from low to high includes it.
By their numbers in this assay, from the lowest: compound 1; then compound 2; then compound 3.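

In this assay, the position on a saturated chain carbon bound to an amide-type nitrogen tolerates (isopentylamino)methyl, but at a cost larger than the earlier step showed, with a 7.7-fold higher number from compound 1 to compound 3 (0.89 log units; beyond the scatter) beyond that of the first pair. Dropping the six-membered ring does not alone fix the number here: compound 2 and compound 3 both lack it, yet the change between them gives a 3.6-fold higher number from compound 2 to compound 3 (0.56 log units; beyond the scatter) in this series. Nothing measured here accounts for either step.

The compounds shown leave open whether a shorter group on the amine, such as ethyl, or a ring-bearing one, such as cyclohexylmethyl, would behave as isopentyl does. They also leave open whether a hydroxyl group could stand in place of the amine at this position.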